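The source may hold more compounds than are shown below. What is called first, only, known or untested is meant among the compounds shown, and "the series" means these compounds.

Measured compounds:
- compound 1 `CCOC(=O)N1CCN(C(=S)SCC(O)Cn2c([N+](=O)[O-])cnc2C)CC1`: 1610000 nM
- compound 2 `CCN(CC)C(=S)SCC(O)Cn1c([N+](=O)[O-])cnc1C`: 2460000 nM

In a toxicity assay on HeLa cells (Homo sapiens) for cytotoxicity, read by MTT assay, with a stated time of 24 h (a lower number here means a stronger inhibitor, a higher number a weaker inhibitor), compound 1 gives 1610000 nM and compound 2 gives 2460000 nM. Compound 1 stands at one end of these two numbers and compound 2 at the other, but the gap between them lies within the scatter of repeated measurements, so the two are not told apart. Compound 3 `Cc1ncc([N+](=O)[O-])n1CC(O)CSC(=S)N1CCN(C(=O)OC(C)(C)C)CC1` has not yet been measured in this assay. It differs from compound 1 in one place: tert-butyl in place of ethyl on an oxygen next to a carbonyl group. Going by the values given here, no pair of measured compounds shows what this change does; compounds 1 and 2 differ elsewhere. With nothing to point either way, a step from compound 1 to compound 3 of no more than the scatter is expected, in either direction. Compound 3 is therefore estimated to give about 1600000 nM in this assay, with a range from 600000 nM to 4500000 nM, which means an expected step of a 1.0-fold lower number from compound 1 to compound 3 (0.00 log units; within the scatter).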

Compound 3, half-maximal inhibitory concentration: 689000 nM
For compound 3 the middle estimate is 2.3-fold (0.37 log units) above the measured one; the measured number falls inside the stated range.
By their numbers in this assay, from the lowest: compound 3; then compounds 1 and 2 (each within the scatter of the next).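

In this assay, going by these compounds alone, placing tert-butyl in place of ethyl on an oxygen next to a carbonyl group gives a 2.3-fold lower number from compound 1 to compound 3 (0.37 log units; beyond the scatter) and is the first change here to produce a readable difference. The earlier pair could not show this, since compound 1 and compound 2 differ elsewhere and are not told apart, so this oxygen substituent is now known to be a place where the number can move. The step is modest and rests on a single pair, and nothing shown here explains it.

On these data alone, whether the number would shift further with an isopropyl or benzyl group on this oxygen remains open, as does the effect of a longer chain there. As far as these compounds go, it is also open whether replacing the oxygen with an amine nitrogen would keep the step seen with tert-butyl.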